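Will pyrrolidin-1-yl undo the gain of compound 3?

A few compounds are considered here, and "the series" means these few. Any claim that something is new, unique, unknown or untested is made for them only; others in the source may bear on it.

Values in a functional assay on ECa-109 cells for inhibition, with ECa-109 cell line (Homo sapiens) as the target, read by sulforhodamine B assay; on this read-out lower numbers stand for stronger inhibition and higher numbers for weaker inhibition:
- Compound 1 `O=C1C=C(N2CCC2)C(=O)c2c1nc1n2[C@H]2OC[C@@H](O)[C@H]2OC1`: > 16000 nM (a limit)
- Compound 2 `CCCN(CCC)C1=CC(=O)c2nc3n(c2C1=O)[C@H]1OC[C@@H](O)[C@H]1OC3`: > 16000 nM (a limit)
- Compound 3 `Cc1ccc(NC2=CC(=O)c3nc4n(c3C2=O)[C@H]2OC[C@@H](O)[C@H]2OC4)cc1`: 3480 nM

For the measured compounds named here, compound 3 is the strongest of the three and the only one with a true number in this assay. Compound 1 and compound 2 both stand at the limit of > 16000 nM in this assay, at which 2 of the 3 values shown sit.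

The next step leads to compound 4 `O=C1C=C(N2CCCC2)C(=O)c2c1nc1n2[C@H]2OC[C@@H](O)[C@H]2OC1`: pyrrolidin-1-yl in place of (4-methylphenyl)amino on a double-bonded ring carbon. In words, pyrrolidin-1-yl takes the place of (4-methylphenyl)amino on a double-bonded ring carbon.

Going by the values given here, two measured steps bear on this change. They involve the same position. Bringing in (4-methylphenyl)amino gave an at least 4.5-fold lower number from compound 1 to compound 3 (0.66 log units; beyond the scatter). It also gave an at least 4.5-fold lower number from compound 2 to compound 3 (0.66 log units; beyond the scatter). The third comparison, a step that the two limits leave unreadable from compound 1 to compound 2, offers no size to work with.

Pyrrolidin-1-yl looks more like azetidin-1-yl than like (4-methylphenyl)amino, so the gain seen in an at least 4.5-fold lower number from compound 1 to compound 3 (0.66 log units; beyond the scatter) is expected to be lost. The expected direction is therefore towards a higher number, and the assay may well report only a limit again. The estimated change is a 5.7-fold higher number from compound 3 to compound 4 (0.76 log units; beyond the scatter), a modest step or larger. For compound 4 the estimated value is 20000 nM, with an expected range from 7000 nM to 40000 nM.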

Compound 4, half-maximal inhibitory concentration: > 16000 nM
Compound 4 was reported as a limit (the forecaster's own chance of this, stated with the estimate: 70%); the middle value lies beyond the limit too.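

In this assay, for the compounds shown here, the earlier steps showed only that (4-methylphenyl)amino did better than azetidin-1-yl and dipropylamino, and this result adds a third group to that comparison, with an at least 4.5-fold higher number from compound 3 to compound 4 (0.66 log units; beyond the scatter). Across the compounds shown, the cyclic amines of two ring sizes and the open-chain dipropylamino group all end at the same limit, which is a limit and not a number: the limit of > 16000 nM in this assay, at which 3 of the 4 values shown sit. Compound 3 therefore remains the only one with a true number, and the steps among compound 1, compound 2 and compound 4 cannot be read, so nothing can be said about any order among these three groups.

The group in compound 3 differs from the other three in two ways at once, carrying both an aromatic ring and a hydrogen-bond donor, so these compounds cannot show which of the two matters. Cyclohexylamino would keep the donor without the aromatic ring, while methyl(4-methylphenyl)amino would keep the aromatic ring without the donor, and values for these two groups could begin to separate the two features.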